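The source may report more compounds than this note shows. Statements on the series, on what has been measured and on what is new or still open speak of the compounds shown alone.

Working notes on the series.

Compound 2, `Nc1nc(N2CCN(C(=O)COc3ccc(Cl)cc3)CC2)c2nc(Cc3ccc(F)cc3)sc2n1`, holds the highest of the two numbers measured in a functional assay on cells (Lymphocyte, Homo sapiens) (a lower number here means a stronger inhibitor, a higher number a weaker inhibitor), giving 700 nM. Compound 3, `Nc1nc(N2CCN(C(=O)COc3ccccc3)CC2)c2nc(-c3ccc(F)cc3)sc2n1`, gives 90 nM in this assay. Compound 1, `CC(C)(Oc1ccc(Cl)cc1)C(=O)N1CCN(c2nc(N)nc3sc(-c4ccc(F)cc4)nc23)CC1`, gives > 10000 nM in this assay, which is a limit and not a number, as noted by the limit of > 10000 nM in this assay, at which 1 of the 3 values shown sits. Within the data shown here, the only step measured between compounds differing in one place is an at least 110-fold lower number from compound 1 to compound 3 (2.04 log units; beyond the scatter), a change at the carbonyl carbon and not at the five-membered ring.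

Compound 4, `Nc1nc(N2CCN(C(=O)COc3ccc(Cl)cc3)CC2)c2nc(-c3ccncc3)sc2n1`, is not yet measured. It differs from compound 2 by pyridin-4-yl in place of 4-fluorobenzyl on an aromatic carbon. Among the measured compounds shown here, no measured step touches this place; compound 2 and compound 3 differ at two places at once, so their values only show that the pair with the directly attached six-membered ring sits at the lower number. The step to compound 4 is therefore expected as a 2.3-fold lower number from compound 2 to compound 4 (0.37 log units; beyond the scatter), a modest move toward a lower number with wide uncertainty. Compound 4 is estimated at 300 nM in this assay, between 60 nM and 1500 nM.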

Compound 4, half-maximal inhibitory concentration: 40 nM
The estimate for compound 4 lay 7.5-fold (0.88 log units) above the measured number, and the stated range ends above it.
By their numbers in this assay, from the lowest: compound 4; then compound 3; then compound 2. At a limit, above all of these: compound 1.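

The substituent on the aromatic carbon of the five-membered ring, next to the ring nitrogen and next to the ring sulfur, now has a single-place step of its own: in this assay, pyridin-4-yl in place of 4-fluorobenzyl gives an 18-fold lower number from compound 2 to compound 4 (1.24 log units; beyond the scatter) with the 4-chlorophenoxyacetyl side unchanged. Among these compounds, compound 2 and compound 3 differ at two places at once, so only this step shows that the group at this position alone can move the number by a large amount. No measured property given for the series bears on this step.

The step changes the ring and its attachment together, leaving open whether the ring nitrogen or the direct attachment carries the change. Phenyl, pyridin-3-yl or pyridin-2-yl on the same carbon would separate the two, and a morpholine or an aminomethyl group would test the position further.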